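A few compounds are considered here, and "the series" means these few. Any claim that something is new, unique, unknown or untested is made for them only; others in the source may bear on it.

The compounds here share one core and differ only in what sits on the aromatic ring at the far end. Compound 1 `CC1=CC[C@H](C(C)(C)NC(=S)N/N=C/c2ccccc2)CC1` carries that ring bare. In a functional assay on OVCAR-3 cells (Homo sapiens) for inhibition, read by sulforhodamine B assay, with a stated time of 48 h (on this read-out higher numbers stand for weaker inhibition of growth and lower numbers for stronger inhibition of growth), compound 1 gives 20600 nM, and the two other numbers recorded so far both lie within the scatter of it, so no ranking among the three can be drawn. Compound 2 `CC1=CC[C@H](C(C)(C)NC(=S)N/N=C/c2ccc(Cl)cc2)CC1` adds a chloro group to the ring and gives 26400 nM in this assay; compound 3 `CC1=CC[C@H](C(C)(C)NC(=S)N/N=C/c2ccccc2[N+](=O)[O-])CC1` adds a nitro group and gives 25800 nM. The step of a 1.3-fold higher number from compound 1 to compound 2 (0.11 log units; within the scatter) and the step of a 1.3-fold higher number from compound 1 to compound 3 (0.10 log units; within the scatter) are each too small to count as a real change. Compound 4 `CC1=CC[C@H](C(C)(C)NC(=S)N/N=C/c2cccc([N+](=O)[O-])c2)CC1` is the untested member: nitro in place of hydrogen on an aromatic carbon. The two measured steps bear on it directly, since each adds a single group to the same ring of compound 1 and neither moved the number beyond the scatter. The expectation for compound 4 in this assay is therefore a step of a 1.2-fold higher number from compound 1 to compound 4 (0.07 log units; within the scatter), that is, nothing beyond the scatter. Compound 4 is accordingly estimated at 24000 nM, with a range from 12000 nM to 48000 nM.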

Compound 4, concentration for total growth inhibition: > 100000 nM
Compound 4 gave a limit, no number; the forecaster's own chance of this, stated with the estimate: 5%; at least 4.1-fold (0.61 log units) between middle value and limit.
By their numbers in this assay, from the lowest: compounds 1, 3 and 2 (each within the scatter of the next). At a limit, above all of these: compound 4.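

This result shows that a nitro group on the ring does not always leave the number within the scatter. Compound 4, with nitro meta to a large group, gives a limit in this assay and not a number: the limit of > 100000 nM in this assay, at which 1 of the 4 values shown sits. Even so, the change is readable as an at least 4.8-fold higher number from compound 1 to compound 4 (0.68 log units; beyond the scatter), which means weaker inhibition of growth than with the bare ring, whereas the earlier single additions to that ring gave no change that could be told from the scatter. Compound 3 carries the same nitro group on a different carbon of the ring and gives 25800 nM, so in this pair the place of the group on the ring, and not its presence alone, separates the two results.

The compounds shown have only nitro meta to a large group, so it remains open whether an amine, a carboxylic acid or a methyl group there would also weaken growth inhibition. They also give no reason for the shift, and a single pair cannot show whether the effect of this position extends beyond these compounds.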